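A few compounds are considered here, and "the series" means these few. Any claim that something is new, unique, unknown or untested is made for them only; others in the source may bear on it.

The three measured compounds share one core, a long chain ending in a phenyl ring attached through a carbonyl to a five-membered aromatic ring, and differ only in the group carried on that ring. Compound 1 `Nc1cccc(-c2cnc(C(=O)CCCCCCc3ccccc3)o2)c1` bears a 3-aminophenyl group and in an assay (Rattus norvegicus) for inhibition of Fatty-acid amide hydrolase 1 (Homo sapiens) (on this read-out lower numbers stand for stronger inhibition and higher numbers for weaker inhibition), compound 1 gives 19 nM. Compound 2 `COc1ccnc(-c2cnc(C(=O)CCCCCCc3ccccc3)o2)c1` bears a 4-methoxypyridin-2-yl group, and in this assay compound 2 gives 0.8 nM, which is a 24-fold lower number from compound 1 to compound 2 (1.38 log units; beyond the scatter). Compound 3 `O=C(CCCCCCc1ccccc1)c1ncc(-c2ncccc2C(=O)O)o1` bears a 3-carboxypyridin-2-yl group. In this assay compound 3 gives > 50 nM, which is a limit of the assay and not a number, so compound 3 stands at the limit of > 50 nM in this assay, at which 1 of the 3 values shown sits. Against the others this is an at least 2.6-fold higher number from compound 1 to compound 3 (0.42 log units; beyond the scatter) and an at least 62-fold higher number from compound 2 to compound 3 (1.79 log units; beyond the scatter).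

Compound 4 `O=C(CCCCCCc1ccccc1)c1ncc(Cl)o1` is the next step from compound 3: chloro in place of 3-carboxypyridin-2-yl on an aromatic carbon. Among the measured compounds shown here, no measured step involves a chloro group, so the two steps ending at compound 3 are the only guide, and both show that the 3-carboxypyridin-2-yl group goes with weaker inhibition than the other two groups. Compound 4 is therefore expected to give a lower number than compound 3, the step being estimated as an at least 2.5-fold lower number from compound 3 to compound 4 (0.39 log units; beyond the scatter). For compound 4 the estimate is 20 nM, with a range from 5 nM to 80 nM.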

Compound 4, inhibition constant: 5 nM
For compound 4 the middle estimate is 4.0-fold (0.60 log units) above the measured one; low and high end bracket the measured number.
By their numbers in this assay, from the lowest: compound 2; then compound 4; then compound 1. At a limit, above all of these: compound 3.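

Until now, every group on this carbon, the one next to the ring oxygen, carried a six-membered aromatic ring, so it was unclear whether a ring was needed there at all. In this assay, a single chlorine atom with no ring gives a 3.8-fold lower number from compound 1 to compound 4 (0.58 log units; beyond the scatter), so a ring at this position is not required for strong inhibition, although the right ring can still do better, as chloro in place of 4-methoxypyridin-2-yl gives a 6.3-fold higher number from compound 2 to compound 4 (0.80 log units; beyond the scatter). Chloro in place of 3-carboxypyridin-2-yl gives an at least 10-fold lower number from compound 3 to compound 4 (1.00 log units; beyond the scatter), and the size of that step rests on a value for compound 3 that is a limit of the assay and not a number: the limit of > 50 nM in this assay, at which 1 of the 4 values shown sits.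

On these data alone, whether another small group on this carbon, such as bromine, a methyl group or a nitrile, would match or beat chloro remains open. As far as these compounds go, it also remains open how much of the edge of compound 2 belongs to its methoxy group and how much to its pyridine ring, a question that a plain pyridin-2-yl group would help to settle.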